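Iodine for Bromine in a Small Urea Series

The compounds below may be only part of what the source reports. "The series", "measured", "known", "first", "only" and "open" are said of these compounds alone.

Of the compounds shown here, three of one shared core have been measured, and a fourth has not. Compound 1 `C[C@@H](NC(=O)Nc1ccccc1Br)c1ccccc1` carries bromo ortho to a large group; in an ADME assay on the whole organism with Oryza sativa as the target, tested at 10 uM (a lower number here means a stronger effect, a higher number a weaker effect of the compound at the concentration tested), compound 1 gives 94%. Compound 3 `C[C@@H](NC(=O)Nc1ccccc1I)c1ccccc1` differs from compound 1 by iodo in place of bromo on an aromatic carbon, and in this assay compound 3 gives 96%; the step is a number 2 percentage points higher from compound 1 to compound 3 (within the scatter). Compound 2 `C[C@@H](NC(=O)Nc1ccc(Br)cc1)c1ccccc1` has the same atoms as compound 1 joined differently; the difference between the two cores is not broken down here. In this assay compound 2 gives 87%, which lies within the scatter of compound 1 and of compound 3. Compound 4 `C[C@@H](NC(=O)Nc1ccc(I)cc1)c1ccccc1` differs from compound 2 by iodo in place of bromo on an aromatic carbon. This is the same kind of change as from compound 1 to compound 3, though the place differs: ortho to a large group there, para to a large group here. Because the step of a number 2 percentage points higher from compound 1 to compound 3 (within the scatter) stayed within the scatter, a small step is expected here as well: a number 2 percentage points higher from compound 2 to compound 4 (within the scatter). Compound 4 is therefore estimated at 89%, with a range from 80% to 97%.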

Compound 4, a percentage reported as activity, at one concentration (the size of the read-out at that concentration, not a potency): 85%
The estimate for compound 4 lay 4 percentage points above the measured number; the measured number falls inside the stated range.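

Putting iodo in place of bromo on the second core gives a number 2 percentage points lower from compound 2 to compound 4 (within the scatter), so this step is small as well. Set side by side, the two steps show no real difference, and in this assay the change carries over from one core to the other as far as these compounds can tell: the same change on two cores in this assay, a number 2 percentage points higher (within the scatter) from compound 1 to compound 3 and a number 2 percentage points lower (within the scatter) from compound 2 to compound 4, 4 percentage points apart, within the scatter of two such steps This shows only that the swap left the number within the scatter on both of these two cores; it does not show that the change has a shared effect of any particular size or direction, and two pairs cannot establish a rule for the series.

As far as these compounds go, all four compounds carry a halogen, so it remains open whether an amine, a methyl group or a carboxylic acid in the same place, para to a large group, would also stay within the scatter or would shift the number further. From the compounds shown here alone, it also remains open whether the iodo-for-bromo step would stay this small on a core giving a much lower number in this assay.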